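The source may hold more compounds than are shown below. What is called first, only, known or untested is meant among the compounds shown, and "the series" means these compounds.

Measured so far:
compound 1, `O=C(NC(=S)NCc1cc(C(F)(F)F)cc(C(F)(F)F)c1)c1ccccc1`: 10%
compound 2, `O=C(NC(=S)NCc1ccc(C(F)(F)F)cc1)c1ccccc1`: "not active" (no number reported)

In an assay on isolated protein for inhibition of protein deacetylase HDAC6 (Homo sapiens), read by fluorescence, tested at 100 uM (on this read-out lower numbers stand for less inhibition and higher numbers for more inhibition at the one concentration tested (going by the name of the read-out)), compound 1 gives 10%. Compound 2, in the same read-out, is reported only as "not active" (no number reported), with no number attached, so it stands without a single value on this read-out; all that the two entries show is that both compounds sit at the low end, with neither giving much inhibition at the concentration tested. Compound 3, `O=C(NC(=S)NCc1ccc(-c2ccccc2)cc1)c1ccccc1`, is the next step from compound 2. The change is phenyl in place of trifluoromethyl on an aromatic carbon. For the measured compounds named here, no measured pair of this kind is at hand, so the size of the step is unknown; the expectation is for no step beyond the scatter in this assay, with the read-out remaining low. For compound 3 the estimate in this assay is 10%, with a range from 0% to 30%. Should compound 3 also come back without a number, that would be in line with compound 2.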

Compound 3, a percentage reported as inhibition, at one concentration (the size of the read-out at that concentration, not a potency): "not active" (no number reported)
Compound 3 has no reported number here; there is nothing to compare the estimate with.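

In this assay, compound 2 and compound 3 are both reported as "not active" with no number, and no step can be read between them. As far as these compounds go, whether phenyl in place of trifluoromethyl shifts inhibition at all remains open. No evidence at hand bears on this result.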